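This account rests on a few compounds, and the source may have more. Where it says the series, first, only, none or still open, it means among the compounds named here.

Compound 1, `CC(C)=CCOc1c(C)c(C)c2c(c1C)CCC(C)(COc1ccc(/C=C3\SC(=O)NC3=O)cc1)O2`, gives 76% in a functional assay on MCF7 cells (Homo sapiens), tested at 2.5 uM; on this read-out higher numbers stand for a weaker effect at the one concentration tested and lower numbers for a stronger effect.
Compound 2, `C=CCOc1c(C)c(C)c2c(c1C)CCC(C)(COc1ccc(/C=C3\SC(=O)NC3=O)cc1Br)O2`, gives 102% in this assay.

Of these two numbers, compound 2 stands highest, and the gap to compound 1 lies beyond the scatter, so compound 2 shows the weaker effect of the two. Among the measured compounds shown here, the two compounds differ in more than one place, so no single step between them can be read off.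

Compound 3, `CC(C)=CCOc1c(C)c(C)c2c(c1C)CCC(C)(COc1ccc(/C=C3\SC(=O)NC3=O)cc1Br)O2`, is not yet measured in this assay. It differs from compound 2 by 2-methylprop-1-en-1-yl in place of vinyl on a saturated chain carbon bound to an oxygen on an aromatic ring. The change adds two carbons to a chain that is already present and leaves everything else untouched. Since compound 2 in this assay gives 102%, a value close to no effect, only a small step is expected, downward if any, and it may well stay within the scatter. Compound 3 is therefore estimated at 93%, with a range from 72% to 110%. This amounts to an expected step of a number 9 percentage points lower from compound 2 to compound 3 (within the scatter), small and not clearly beyond the scatter.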

Compound 3, a percentage reported as activity, at one concentration (the size of the read-out at that concentration, not a potency): 96%
Estimate against measurement, compound 3: 3 percentage points below; measured number inside the range.
By their numbers in this assay, from the lowest: compound 1; then compounds 3 and 2 (each within the scatter of the next).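

In this assay, going from allyl to 3-methylbut-2-en-1-yl with the bromo group in place gives a number 6 percentage points lower from compound 2 to compound 3 (within the scatter) and so cannot be told from no change at this position. Among the compounds shown here, compounds 1 and 3 carry the same (3-methylbut-2-en-1-yl)oxy group and provide the first single-place reading of the bromo group: bromo in place of hydrogen on an aromatic carbon gives a number 20 percentage points higher from compound 1 to compound 3 (beyond the scatter) and marks a modest loss of effect at the one concentration tested.

The compounds shown leave open whether the chain change would also stay so small with hydrogen in place of the bromo group. They also leave open how a chloro or methoxy group on that aromatic carbon, or a benzyl group or longer chain on the oxygen, would read. No measurement at hand accounts for either step.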